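The source may hold more compounds than are shown below. What is called first, only, known or untested is meant among the compounds shown, and "the series" means these compounds.

Measured in a functional assay on MGC-803 cells (Homo sapiens) for inhibition, read by sulforhodamine B assay; a lower number here means a stronger inhibitor, a higher number a weaker inhibitor:
- compound 1 `O=C1C=C(N2CCC2)C(=O)c2c1nc1n2[C@H]2OC[C@@H](O)[C@H]2OC1`: > 16000 nM, a limit of the assay
- compound 2 `COc1ccc(NC2=CC(=O)c3nc4n(c3C2=O)[C@H]2OC[C@@H](O)[C@H]2OC4)cc1`: 1680 nM
- compound 3 `Cc1ccc(NC2=CC(=O)c3nc4n(c3C2=O)[C@H]2OC[C@@H](O)[C@H]2OC4)cc1`: 1420 nM

Compound 3 reads 1420 nM, level with compound 2 at 1680 nM. The step of a 1.2-fold lower number from compound 2 to compound 3 (0.07 log units; within the scatter) stays within the scatter.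

The next structure is compound 4 `O=C1C=C(N2CCCC2)C(=O)c2c1nc1n2[C@H]2OC[C@@H](O)[C@H]2OC1`, and its change from the reference is pyrrolidin-1-yl in place of (4-methylphenyl)amino on a double-bonded ring carbon. In words, pyrrolidin-1-yl stands in place of (4-methylphenyl)amino on a double-bonded ring carbon.

For the measured compounds named here, two measured steps bear on this, each replacing azetidin-1-yl with a substituted phenylamino group: an at least 9.5-fold lower number from compound 1 to compound 2 (0.97 log units; beyond the scatter) and an at least 11-fold lower number from compound 1 to compound 3 (1.05 log units; beyond the scatter). Both lie beyond the scatter, and both run opposite to the change now in view. Their sizes are only bounded, and neither involves pyrrolidin-1-yl, so they are a rough guide.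

The expectation rests on compound 1, which reads > 16000 nM, again a limit. A clearly higher number, meaning weaker inhibition, is expected, with an estimated size of a 6.3-fold higher number from compound 3 to compound 4 (0.80 log units; beyond the scatter). A result for compound 4 could also end at the limit of > 16000 nM in this assay, at which 1 of the 3 values shown sits, and give no number. For compound 4 the estimate is 9000 nM, with an expected range of 3000 nM to 27000 nM.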

Compound 4, half-maximal inhibitory concentration: > 16000 nM
Compound 4 was reported as a limit; the forecaster's own chance of this, stated with the estimate: 40%; middle value at least 1.7-fold (0.24 log units) from the limit.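

In this assay compound 4 gives > 16000 nM, which is a limit of the assay and not a number. For the compounds shown here, exchanging the phenylamino groups for pyrrolidin-1-yl on the double-bonded ring carbon gives an at least 11-fold higher number from compound 3 to compound 4 (1.05 log units; beyond the scatter) and an at least 9.5-fold higher number from compound 2 to compound 4 (0.97 log units; beyond the scatter), so the low reading seen for azetidin-1-yl is not tied to that one ring size: among the four compounds, both non-aromatic ring amines sit at the limit, both substituted phenylamino groups give measurable values, and no compound goes against this. The step between compound 1 and compound 4 cannot be read, and the two ring sizes cannot be ordered: the limit of > 16000 nM in this assay, at which 2 of the 4 values shown sit.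

The compounds shown do not separate the aromatic ring from the amino hydrogen as the feature that tracks with measurable inhibition; butylamino, with the hydrogen but no aromatic ring, and methyl(phenyl)amino, with the aromatic ring but no hydrogen, would pull the two apart. On the aromatic ring only methyl and methoxy appear, so a carboxylic acid or a basic amine at that site remains an open question.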